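The source may hold more compounds than are shown below. What is called first, only, known or untested is meant among the compounds shown, and "the series" means these compounds.

Compound 3, `CCCC[S+]([O-])c1sc2nc(-c3ccccc3)nc(-c3ccccc3)c2c1N`, gives 4.9 nM in an assay for inhibition of 15-hydroxyprostaglandin dehydrogenase [NAD(+)] (Homo sapiens), read by fluorescence, with a stated time of 15 min, in the presence of a further agent that is not named here; on this read-out lower numbers stand for stronger inhibition and higher numbers for weaker inhibition. Among the three compounds measured it holds the second highest number: compound 2, `Nc1c([S+]([O-])CCCCl)sc2nc(-c3cccs3)cc(-c3ccccc3)c12`, gives 4 nM, a value that lies within the scatter of compound 3, while compound 1, `CCCC[S+]([O-])c1sc2nc(-c3nccs3)cc(-c3ccc(C(=O)OC)cc3)c2c1N`, gives 15.1 nM, a number higher than that of compound 3 by more than the scatter allows.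

Compound 4, `CCCC[S+]([O-])c1sc2nc(-c3nccn3C)nc(-c3ccccc3)c2c1N`, has not yet been measured. It differs from compound 3 in one place: 1-methyl-1H-imidazol-2-yl in place of phenyl on an aromatic carbon. Among the compounds with values here, no measured pair shows this same exchange, so the size of the step rests on the wider picture alone. Both compound 1 and compound 2 carry a five-membered heteroaryl group in the corresponding position and return numbers that span the value of compound 3, which gives no firm direction. The step of a 1.6-fold higher number from compound 3 to compound 4 (0.21 log units; within the scatter) is therefore expected to be modest, possibly a slight rise in the number. For compound 4 a value of 8 nM is estimated, with a range from 2.5 nM to 25 nM.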

Compound 4, half-maximal inhibitory concentration: 3.7 nM
Compound 4: middle estimate off by 2.2-fold (0.33 log units), on the high side; low and high end bracket the measured number.
By their numbers in this assay, from the lowest: compounds 4, 2 and 3 (each within the scatter of the next); then compound 1.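

In this assay, 1-methyl-1H-imidazol-2-yl in place of phenyl on the aromatic carbon between two ring nitrogen atoms gives a 1.3-fold lower number from compound 3 to compound 4 (0.12 log units; within the scatter), so at this position the exchange leaves no change that can be told from the scatter. Within the data shown here, compound 1 and compound 2 each differ from compound 3 in more than one place, so only this pair isolates the exchange, showing that a five-membered aromatic ring with 2 hetero atoms can stand here in place of a six-membered aromatic ring of carbon only. Nothing available explains this result.

The compounds shown leave open whether the same carbon would tolerate a non-aromatic group, such as a morpholine or a simple amine, or a carboxylic acid. They also leave open whether the imidazole without its methyl group would give a similar number.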